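This account rests on a few compounds, and the source may have more. Where it says the series, first, only, none or still open, it means among the compounds named here.

Two compounds share one core and differ only in the ring hanging from the double-bonded chain carbon. Compound 1 `CCOC(=O)C1=C(Nc2ccccc2)S/C(=C\c2ccc(O)c(O)c2)C1=O` carries a 3,4-dihydroxyphenyl there, and in a functional assay on JAR cells (Homo sapiens) for inhibition, read by MTT assay, with a stated time of 72 h, tested at 10 uM (a lower number here means less inhibition, a higher number more inhibition at the concentration tested (going by the name of the read-out)), compound 1 gives 48.7%. Compound 2 `CCOC(=O)C1=C(Nc2ccccc2)S/C(=C\c2ccc(C(=O)O)cc2)C1=O` carries a 4-carboxyphenyl instead, and in this assay compound 2 gives 16.8%. The swap is a step of a number 31.9 percentage points lower from compound 1 to compound 2 (beyond the scatter), so compound 2 stands lowest of the two numbers measured.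

Compound 3 `CCOC(=O)C1=C(Nc2ccccc2)S/C(=C\c2cccc(C(=O)O)c2)C1=O` is the next step. Its difference from compound 2 is 3-carboxyphenyl in place of 4-carboxyphenyl on a double-bonded chain carbon bound to a double-bonded ring carbon. Within the data shown here, no measured step concerns moving a carboxyl group from one ring spot to another; the only step seen, from compound 1 to compound 2, exchanges one whole ring for another and cannot say how far this smaller rearrangement will reach. A step within the scatter, or at most a modest one, is therefore expected, with no preferred direction. Compound 3 is expected to give about 20%, between 5% and 40%, a change of a number 3.2 percentage points higher from compound 2 to compound 3 (within the scatter) from compound 2.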

Compound 3, a percentage reported as inhibition, at one concentration (the size of the read-out at that concentration, not a potency): 50.6%
Compound 3: middle estimate off by 30.6 percentage points, on the low side; measured number outside the range, above it.
By their numbers in this assay, from the lowest: compound 2; then compounds 1 and 3 (each within the scatter of the next).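

In this assay, the spot the carboxyl group occupies on the ring matters a great deal: the two rings have the same atoms joined differently, yet the swap gives a step of a number 33.8 percentage points higher from compound 2 to compound 3 (beyond the scatter), as large as the earlier exchange of one whole ring for another. The step of a number 1.9 percentage points higher from compound 1 to compound 3 (within the scatter) shows that a carboxyl-bearing ring can read like the 3,4-dihydroxyphenyl ring, so among these compounds the low number goes with the 4-carboxyphenyl ring of compound 2, not with every carboxyphenyl ring. No measurement available here explains why moving this one group has so large an effect.

Still open, on these data alone, is whether an amine or a methyl ester in place of the carboxyl group of compound 3 would keep this number. Among these compounds, with only three compounds, all sharing one core, it is also open whether this pattern holds on other cores.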